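Acyl swap at the ring nitrogen of the shared core

This account rests on a few compounds, and the source may have more. Where it says the series, first, only, none or still open, it means among the compounds named here.

Compound 1 `CCCCCCCCC(=O)N1c2ccccc2CC1C(=O)Nc1ccc(C(F)(F)F)cc1` is tested in a functional assay on PC-3 cells (Homo sapiens) for cytotoxicity (a higher number here means a weaker inhibitor of growth, a lower number a stronger inhibitor of growth), where compound 1 gives 1860 nM. Compound 2 `CC(C)(C)OC(=O)N1c2ccccc2CC1C(=O)Nc1cc(C(F)(F)F)ccc1C(F)(F)F` gives 838 nM in this assay. Of the two numbers, compound 1 holds the higher one, and the gap down to compound 2 is beyond the scatter. Compound 3 `Cc1ccc(S(=O)(=O)N2c3ccccc3CC2C(=O)Nc2cc(Cl)cc(Cl)c2)cc1` reaches only the limit of this assay, reported as > 10000 nM. One of the three results shown sits at that limit (the limit of > 10000 nM in this assay, at which 1 of the 3 values shown sits). Compound 4 `CC(C)(C)OC(=O)N1c2ccccc2CC1C(=O)Nc1ccc(C(F)(F)F)cc1` has not yet been measured. It differs from compound 1 by tert-butoxy in place of octyl on a carbonyl carbon. Within the data shown here, no measured pair differs in exactly this way; compound 2 carries the same tert-butoxycarbonyl as compound 4 but differs from it elsewhere, so the values of compound 1 and compound 2 give only a loose pointer. Compound 4 is expected to give about 1300 nM, between 400 nM and 4000 nM. The step of a 1.4-fold lower number from compound 1 to compound 4 (0.16 log units; within the scatter) is expected to be small, toward a lower number but within the scatter.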

Compound 4, concentration for 50% growth inhibition: 2020 nM
Estimate against measurement, compound 4: 1.6-fold (0.19 log units) below; the range from low to high includes it.
By their numbers in this assay, from the lowest: compound 2; then compounds 1 and 4 (each within the scatter of the next). At a limit, above all of these: compound 3.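

In this assay, among these compounds, the one pair differing in a single place gives a 1.1-fold higher number from compound 1 to compound 4 (0.04 log units; within the scatter), the first direct reading at this carbonyl carbon on the amide-type ring nitrogen. With the rest of the structure held constant, octyl and tert-butoxy are interchangeable here within the scatter, although the two groups differ in shape, in heavy-atom content and in the hydrogen-bond acceptor that tert-butoxy brings. Nothing measured here accounts for this level result.

As far as these compounds go, whether the level result extends to other groups at this carbonyl carbon, such as a short acetyl, a benzoyl or a chain ending in an amine, remains open. Also open, from the compounds shown here alone, is whether octyl and tert-butoxy would stay level on a core with a different aryl group on the amide.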